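The source may hold more compounds than are shown below. What is called first, only, known or untested is meant among the compounds shown, and "the series" means these compounds.

Of the compounds shown here, three sharing one core have been measured in an ADME assay on Right cardiac atrium (Cavia porcellus); a lower number here means that less compound is needed, a higher number that more compound is needed for the effect. Compound 1 `CCOC(=O)C1=C(C)NC(C)=C(C(=O)OCC)C1c1c(-c2ccc(F)cc2)nc2sccn12` gives 1650 nM. Compound 2 `CCOC(=O)C1=C(C)NC(C)=C(C(=O)OCC)C1c1c(-c2ccc(F)cc2)nc2sc(C)cn12` gives 23 nM, the lowest of the three, set apart from the others by a 72-fold lower number from compound 1 to compound 2 (1.86 log units; beyond the scatter) and by a 75-fold higher number from compound 2 to compound 3 (1.88 log units; beyond the scatter). Compound 3 `CCOC(=O)C1=C(C)NC(C)=C(C(=O)OCC)C1c1c(-c2ccc(F)cc2)nc2sc(Cl)cn12` gives 1730 nM. Compound 4 `CCOC(=O)C1=C(C)NC(C)=C(C(=O)OCC)C1c1c(-c2cc(OC)ccc2OC)nc2sc(C)cn12` carries a different kind of change: 2,5-dimethoxyphenyl in place of 4-fluorophenyl on an aromatic carbon. Within the data shown here, every measured step altered only the small group on the five-membered aromatic ring, and the remaining one, a 1.0-fold higher number from compound 1 to compound 3 (0.02 log units; within the scatter), stays within the scatter; none touched the 4-fluorophenyl group, so no measured step bears on this change and its size is unknown. With no guide, the expected step is modest, a 6.5-fold higher number from compound 2 to compound 4 (0.81 log units; beyond the scatter). The estimated value for compound 4 is 150 nM, within a wide range from 20 nM to 1500 nM.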

Compound 4, half-maximal effective concentration: 4810 nM
For compound 4 the middle estimate is 32-fold (1.51 log units) below the measured one; measured number outside the range, above it.
By their numbers in this assay, from the lowest: compound 2; then compounds 1 and 3 (each within the scatter of the next); then compound 4.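

In this assay, 2,5-dimethoxyphenyl in place of 4-fluorophenyl gives a 210-fold higher number from compound 2 to compound 4 (2.32 log units; beyond the scatter), so the number depends strongly on this aromatic group as well as on the small group on the five-membered ring. Compound 4 keeps the methyl of compound 2, so that methyl alone does not secure a low number here. No available measurement explains this step.

On these data alone, because the change removes the fluorine and adds both methoxy groups at once, their separate contributions remain open. Plain phenyl or a phenyl carrying a single methoxy group could help separate them, while a phenyl bearing an amine or a carboxylic acid remains an open question.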